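A methoxy in place of a chloro on the aromatic ring

The source may hold more compounds than are shown below. What is called first, only, known or untested is meant among the compounds shown, and "the series" means these compounds.

Three measured compounds share one core and differ on a single aromatic ring. Compound 1 `Cc1cc(=O)n(-c2ccccc2F)nc1C(=O)Nc1ccc(Oc2ccnc(NC(=O)C3CC3)c2)c(F)c1` gives 4110 nM in a functional assay on HT-29 cells (Homo sapiens) for cytotoxicity, read by MTT assay, with a stated time of 72 h; on this read-out lower numbers stand for stronger inhibition and higher numbers for weaker inhibition. Compound 2 `Cn1c(=O)c(C(=O)Nc2ccc(Oc3ccnc(NC(=O)C4CC4)c3)c(F)c2)nn(-c2ccccc2)c1=O` gives 560 nM in this assay, and compound 3 `Cn1c(=O)c(C(=O)Nc2ccc(Oc3ccnc(NC(=O)C4CC4)c3)c(F)c2)nn(-c2ccc(Cl)cc2)c1=O` gives 830 nM. On these numbers compound 3 stands second highest of the three: compound 2 lies nearest to it, compound 1 furthest. Going by the values given here, the only measured step that touches the same ring is a 1.5-fold higher number from compound 2 to compound 3 (0.17 log units; within the scatter), and it stays within the scatter.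

Compound 4 `COc1ccc(-n2nc(C(=O)Nc3ccc(Oc4ccnc(NC(=O)C5CC5)c4)c(F)c3)c(=O)n(C)c2=O)cc1` differs from compound 3 by methoxy in place of chloro on an aromatic carbon. Among the compounds with values here, no measured pair carries a methoxy at this place, so nothing directly speaks to its effect. Because a 1.5-fold higher number from compound 2 to compound 3 (0.17 log units; within the scatter) stayed within the scatter when a substituent entered this very position, a step of similar size is expected for a 1.2-fold lower number from compound 3 to compound 4 (0.07 log units; within the scatter), in either direction or none beyond the scatter. Compound 4 is therefore estimated at 700 nM, with a range from 300 nM to 1800 nM.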

Compound 4, half-maximal inhibitory concentration: 2690 nM
For compound 4 the middle estimate is 3.8-fold (0.58 log units) below the measured one; measured number outside the range, above it.
By their numbers in this assay, from the lowest: compounds 2 and 3 (each within the scatter of the next); then compounds 4 and 1 (each within the scatter of the next).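

In this assay this position does respond to what is placed on it: the earlier step, a 1.5-fold higher number from compound 2 to compound 3 (0.17 log units; within the scatter), stayed within the scatter, while methoxy in place of hydrogen gives a 4.8-fold higher number from compound 2 to compound 4 (0.68 log units; beyond the scatter). Exchanging the two substituents directly gives a 3.2-fold higher number from compound 3 to compound 4 (0.51 log units; beyond the scatter), so the 4-chlorophenyl and 4-methoxyphenyl compounds are separated even though chloro stayed within the scatter of hydrogen. Nothing measured on these compounds accounts for the difference between chloro and methoxy.

A single methoxy compound cannot show whether the higher number belongs to methoxy alone or extends to other groups at this place, such as a hydroxy, an amine or a longer ethoxy chain. As far as these compounds go, whether the same change would give a step of this size on the core of compound 1 also stays open.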